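This account rests on a few compounds, and the source may have more. Where it says the series, first, only, none or still open, it means among the compounds named here.

Series notes. Compound 1 `NCCOc1ccc([C@H]2CC[C@]3(CC2)OOC2(O3)C3CC4CC(C3)CC2C4)cc1` carries the shared core with a short amine-bearing chain on the aromatic oxygen. In a physicochemical assay for solubility, read by nephelometry, measured as kinetic solubility, with a stated time of 30 min (on this read-out higher numbers stand for higher solubility and lower numbers for lower solubility), compound 1 is reported at a limit of the assay, > 100 ug/mL. Compound 2 `O[C@H]1CC[C@H](NCCCOc2ccc([C@H]3CC[C@]4(CC3)OOC3(O4)C4CC5CC(C4)CC3C5)cc2)CC1` differs from compound 1 in one place. In this assay compound 2 likewise sits at a limit of the assay, > 100 ug/mL. The step that the two limits leave unreadable from compound 1 to compound 2 is therefore not readable in size or direction; on the numbers shown compound 2 stands at the limit, as the limit of > 100 ug/mL in this assay, at which 2 of the 2 values shown sit, records. Compound 3 `NCCCCOc1ccc([C@H]2CC[C@]3(CC2)OOC2(O3)C3CC4CC(C3)CC2C4)cc1` has not been measured. Relative to compound 2 the change is aminomethyl in place of (4-hydroxycyclohexyl)amino on a saturated chain carbon, three bonds along the chain from an oxygen on an aromatic ring. Among the compounds with values here, the only measured step, from compound 1 to compound 2, introduced the (4-hydroxycyclohexyl)amino group and left no readable size, so nothing can be carried over in magnitude; compound 3 returns to a primary amine on the chain and resembles compound 1 closely. No step beyond the scatter is expected in this assay, and a further limit seems likely. The estimated step that the limit leaves unreadable from compound 2 to compound 3 is accordingly near nil. For compound 3 the expected value in this assay is 150 ug/mL, within 80 ug/mL to 300 ug/mL.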

Compound 3, solubility: 50 ug/mL
Compound 3: middle estimate off by 3.0-fold (0.48 log units), on the high side; measured number outside the range, below it.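

Compound 3 gives the series its first number that is not a limit: in this assay compound 3 stands at 50 ug/mL. Within the data shown here, this makes the change at this place readable for the first time, at least as a floor, with aminomethyl in place of (4-hydroxycyclohexyl)amino giving an at least 2.0-fold lower number from compound 2 to compound 3 (0.30 log units; that floor lies within the scatter), and 2-aminoethyl in place of amino giving an at least 2.0-fold lower number from compound 1 to compound 3 (0.30 log units; that floor lies within the scatter). Compound 1 and compound 2 each give only a limit, so both steps remain floors with their true size unknown, and neither floor clears the scatter, because the two starting values sit at the assay's limit: the limit of > 100 ug/mL in this assay, at which 2 of the 3 values shown sit.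

With only these compounds, the 4-aminobutyl chain of compound 3 cannot be separated from the end group as the source of the lower number, since compound 3 differs from compound 2 in both the chain and the amine substituent. A 5-aminopentyl chain, a dimethylamino group at the chain end, or a carboxylic acid in place of the amine would show whether the number keeps falling, holds or returns to the limit.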